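The source may hold more compounds than are shown below. What is called first, only, known or untested is meant among the compounds shown, and "the series" means these compounds.

In a functional assay on PRK cells (Oryctolagus cuniculus) (on this read-out higher numbers stand for weaker inhibition and lower numbers for stronger inhibition), compound 2, `N#CCOc1cn([C@H]2C[C@H](O)[C@@H](CO)O2)c(=O)[nH]c1=O`, gives > 400 ug/mL, and this is a limit of the assay, not a number. Compound 3, `C#CCOc1cn([C@H]2C[C@H](O)[C@@H](CO)O2)c(=O)[nH]c1=O`, differs from it in a single exchange, ethynyl in place of cyano on a saturated chain carbon bound to an oxygen on an aromatic ring. Among the measured compounds shown here, only one measured step bears on this change, and only indirectly. Compound 1, `N#Cc1cn([C@H]2C[C@H](O)[C@@H](CO)O2)c(=O)[nH]c1=O`, gives 8 ug/mL in this assay, and the step of an at least 50-fold higher number from compound 1 to compound 2 (1.69 log units; beyond the scatter) is large and beyond the scatter. That step replaces cyano with cyanomethoxy, so it does not test the exchange at hand, although compound 1 at 8 ug/mL shows that the shared core can reach a much lower number. Any measurable result could only lie lower than the limit, so a moderate fall is expected, though another limit remains possible. The expected change is an at least 6.6-fold lower number from compound 2 to compound 3 (0.82 log units; beyond the scatter). For compound 3, the estimated value is 60 ug/mL, with an expected range of 3 ug/mL to 400 ug/mL.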

Compound 3, half-maximal inhibitory concentration: 100 ug/mL
Compound 3: middle estimate off by 1.7-fold (0.22 log units), on the low side; measured number inside the range.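

In this assay, putting ethynyl in place of cyano on this saturated chain carbon gives an at least 4.0-fold lower number from compound 2 to compound 3 (0.60 log units; beyond the scatter), so the group at this place alone can separate a limit from a measurable number, which the earlier step could not show because it replaced the whole substituent. Replacing cyano on the aromatic carbon with propargyloxy still gives a 13-fold higher number from compound 1 to compound 3 (1.10 log units; beyond the scatter), so the measurable number of compound 3 does not recover the level of compound 1. Compound 2 gives only a limit of the assay, not a number, so the first step sets only a floor on the size of the change: the limit of > 400 ug/mL in this assay, at which 1 of the 3 values shown sits.

From the compounds shown here alone, it remains open whether an amine, a carboxylic acid or a chain longer than propargyl at this place would bring the number closer to compound 1 at 8 ug/mL. The compounds shown also cannot tell why ethynyl and cyano differ here.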